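The source may report more compounds than this note shows. Statements on the series, on what has been measured and on what is new or still open speak of the compounds shown alone.

Compound 1 (`CNC(=O)c1cc(C(=O)N[C@H]2CC[C@H](O)CC2)n([C@@H](C)c2ccccc2)n1`): 30%
Compound 2 (`CNC(=O)c1cc(C(=O)N[C@H]2[C@@H]3COC[C@@H]32)c([C@@H](C)c2ccccc2)o1`): 100%

In an ADME assay on the whole organism (Canis lupus familiaris, strain Beagle) for pharmacokinetics, read by LC-MS, with a stated time of 7 h, at a dose of 1 mg/kg by the oral route (a higher number here means that a larger share of the oral dose reaches the circulation, a lower number that a smaller share of the oral dose reaches the circulation), compound 1 holds the lower of the two numbers (30%). Compound 2 gives 100%. The gap between these two compounds lies beyond the scatter. Compound 3 (`CNC(=O)c1cc(C(=O)N[C@H]2CC[C@H](OC)CC2)n([C@@H](C)c2ccccc2)n1`) departs from compound 1 in one place: methyl in place of hydrogen on an oxygen on a saturated carbon (hydroxy to methoxy). Among the compounds with values here, no measured pair shows this change, and compound 2 differs in more than one place, so the direction is uncertain. A modest rise in this assay is expected, an estimated a number 10 percentage points higher from compound 1 to compound 3 (within the scatter) and possibly within the scatter. For compound 3 the expected value is 40% (estimated range 15% to 70%).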

Compound 3, oral bioavailability: 95%
Compound 3: middle estimate off by 55 percentage points, on the low side; measured number above the stated range.
By their numbers in this assay, from the lowest: compound 1; then compounds 3 and 2 (each within the scatter of the next).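

Going from hydroxy to methoxy on the cyclohexyl group is the first single-place change readable in this series, and in this assay it gives a number 65 percentage points higher from compound 1 to compound 3 (beyond the scatter). At this position, a single methyl on the oxygen is therefore enough to shift the oral bioavailability substantially, at least on the core of compound 1. Nothing available explains this step.

From the compounds shown here alone, it remains open whether a longer chain on this oxygen, such as ethyl, would give a similar number. Going by these compounds, it is also open whether an amine in place of the oxygen would keep the higher number.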